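This account rests on a few compounds, and the source may have more. Where it says the series, first, only, none or still open, it means among the compounds named here.

Measured compounds in an ADME assay on HepG2 cells (Homo sapiens) for cytotoxicity, read by resazurin assay, with a stated time of 48 h; on this read-out higher numbers stand for an effect only at larger amounts of compound and lower numbers for an effect already at smaller amounts:
Compound 1 `O=C(Nc1ccc(F)c(-c2nc3ncc(-c4cccc(F)c4)cc3[nH]2)c1)N1CCCC1` gives 28200 nM.
Compound 2 `O=C(Nc1ccc(F)c(-c2nc3ncc(-c4ccc(F)nc4)cc3[nH]2)c1)N1CCCC1` reaches only the assay limit, > 50000 nM.
Compound 3 `O=C(Nc1ccc(F)c(-c2nc3ncc(-c4cc(F)cc(F)c4)cc3[nH]2)c1)N1CCCC1` likewise reaches only the assay limit, > 50000 nM.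

Compound 3 therefore stands at the limit of > 50000 nM in this assay, at which 2 of the 3 values shown sit, with no number of its own. Compound 4 `O=C(Nc1ccc(F)c(-c2nc3ncc(-c4ccc(O)cc4)cc3[nH]2)c1)N1CCCC1` differs from it by 4-hydroxyphenyl in place of 3,5-difluorophenyl on an aromatic carbon. For the measured compounds named here, two measured steps touch this position: an at least 1.7-fold higher number from compound 1 to compound 3 (0.24 log units; that floor lies within the scatter) and a step that the two limits leave unreadable from compound 2 to compound 3. The first gives only a floor that lies within the scatter, the second no size at all, and none of the three measured compounds shows an effect far from the limit in this assay. Compound 4 is therefore expected to sit near that limit as well, with an at least 1.2-fold lower number from compound 3 to compound 4 (0.09 log units; that floor lies within the scatter) as the estimated step. The estimate for compound 4 is 40000 nM, between 15000 nM and 50000 nM.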

Compound 4, half-maximal effective concentration: > 50000 nM
Compound 4 was reported as a limit (the forecaster's own chance of this, stated with the estimate: 50%); at least 1.2-fold (0.09 log units) between middle value and limit.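

In this assay, the result for compound 4 is a limit and not a number, so a ring without fluorine at this position reaches it too: the limit of > 50000 nM in this assay, at which 3 of the 4 values shown sit. For the compounds shown here, replacing 3-fluorophenyl with 4-hydroxyphenyl gives an at least 1.7-fold higher number from compound 1 to compound 4 (0.24 log units; that floor lies within the scatter), which leaves compound 1 as the only compound with a number of its own. The steps from compound 2 and compound 3 to compound 4 cannot be read, as both ends are limits.

Going by these compounds, whether a phenyl ring carrying an amine or a carboxylic acid would also reach the limit stays open. So does how compound 2, compound 3 and compound 4 rank among themselves.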